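Compound 3 to compound 4: swapping the amide side group

The compounds below may be only part of what the source reports. "The series", "measured", "known", "first", "only" and "open" are said of these compounds alone.

- compound 1 `Cc1ccc(-c2cc(C(=O)N[C@H](C)c3ccc(C(F)(F)F)nc3)cc(C(C)(C)O)c2)nc1` gives 95.2%
- compound 2 `Cc1ccc(-c2cc(C(=O)N[C@H](C)c3ccc(C(F)(F)F)[n+]([O-])c3)cc(C(C)(C)O)c2)nc1` gives 62.4%
- compound 3 `Cc1ccc(-c2cc(C(=O)N[C@H](C)c3nc(C)no3)cc(-c3ncccc3F)c2)nc1` gives 99.6%

In an ADME assay on a cell-free system (plasma, Rattus norvegicus) for protein binding, compound 3 has the lowest unbound fraction of the three and gives 99.6%. Compound 4 `Cc1ccc(-c2cc(C(=O)N[C@H](C)c3ccc(C(F)(F)F)nc3)cc(-c3ncccc3F)c2)nc1` differs from compound 3 by 6-(trifluoromethyl)pyridin-3-yl in place of 3-methyl-1,2,4-oxadiazol-5-yl on a saturated chain carbon bound to an amide-type nitrogen and a saturated chain carbon and in no other place.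

Going by the values given here, no measured pair shows this swap. Among the compounds with values here, the one measured step at that place is a 7.8-fold higher unbound fraction from compound 1 to compound 2 (0.89 log units; beyond the scatter) and it alters the entering group itself, so it bears only loosely on the swap.

The estimated step is a 1.3-fold lower unbound fraction from compound 3 to compound 4 (0.12 log units; within the scatter) and nothing beyond the scatter is expected. For compound 4 the expected value is 99.7% within an estimated range of 98.8% to 99.9% in this assay as read.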

Compound 4, plasma protein binding: 98.6%
For compound 4 the middle estimate is 4.7-fold (0.67 log units) (unbound fraction) below the measured one; the whole stated range lies above it.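

In this assay, 6-(trifluoromethyl)pyridin-3-yl in place of 3-methyl-1,2,4-oxadiazol-5-yl gives a 3.5-fold higher unbound fraction from compound 3 to compound 4 (0.54 log units; beyond the scatter), showing that replacing the whole ring at this place moves the read-out beyond the scatter. With that group held, 3-fluoropyridin-2-yl in place of 1-hydroxy-1-methylethyl on an aromatic carbon gives a 3.4-fold lower unbound fraction from compound 1 to compound 4 (0.54 log units; beyond the scatter), so the second place also moves the read-out. No measurement shown accounts for either step.

Open, going by these compounds, is how a carboxylic acid or an amine on the amide side group would read in this assay, and whether the step at the aromatic carbon holds with 3-methyl-1,2,4-oxadiazol-5-yl on the amide.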